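The compounds below may be only part of what the source reports. "The series", "measured", "known", "first", "only" and "open" are said of these compounds alone.

The four compounds share one core, carried by compound 1 `CCN1C(=O)CN(Cc2ccc(-c3cccc(CN4CCCCC4)n3)cc2)C1=O`, compound 2 `O=C1CN(Cc2ccc(-c3ccc(F)c(CN4CCCCC4)n3)cc2)C(=O)N1CC1CCC1`, compound 3 `CCN1C(=O)CN(Cc2ccc(-c3cccc(CC4CCCCC4)n3)cc2)C1=O` and compound 4 `O=C1CN(Cc2ccc(-c3cccc(CN4CCCCC4)n3)cc2)C(=O)N1C1CC1`. In a physicochemical assay for acid dissociation, compound 1 gives 8.8. In this assay compound 2 gives 8.6, and the two numbers lie within the scatter of each other, so neither compound can be placed above the other. For compound 3 the entry in this assay reads "not determined" (no result reported), so no number is available for it, and compound 4 has not yet been measured there.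

Compound 4 differs from compound 1 in one place: cyclopropyl in place of ethyl on an amide-type nitrogen in a ring. Among the compounds with values here, no measured pair in this set isolates such a change, so the expectation rests on the numbers at hand. Because compound 1 gives 8.8 and compound 2 gives 8.6 with different groups on that ring nitrogen, the step from compound 1 to compound 4 is expected to be small. The step of no change at the digits printed from compound 1 to compound 4 (within the scatter) is expected to stay within the scatter. Compound 4 is therefore expected to give about 8.8, within a range from 8.4 to 9.2.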

Compound 4, acid dissociation constant: 9
For compound 4 the middle estimate is 0.20 log units below the measured one, and the stated range covers the measured number.
By their numbers in this assay, from the lowest: compounds 2, 1 and 4 (each within the scatter of the next, the first and the last beyond it).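

The pair of compound 1 and compound 4 isolates a single change at this ring nitrogen, which compound 1 and compound 2 could not do, as they differ in more than one place. In this assay, cyclopropyl in place of ethyl on an amide-type nitrogen in a ring gives a number 0.20 log units higher from compound 1 to compound 4 (within the scatter) and so shows that, on the core of compound 1, this exchange of groups leaves the two compounds indistinguishable. Nothing available accounts for this result.

The compounds shown leave open whether a longer chain such as n-butyl, or a chain carrying an amine or a carboxylic acid, would also stay within the scatter at this nitrogen. They also leave open whether cyclopropyl in place of ethyl would read the same way on a core carrying fluorine, as compound 2 does.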